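Formyl for hydroxy on the shared core

The compounds below may be only part of what the source reports. "The series", "measured", "known", "first", "only" and "open" are said of these compounds alone.

Among the compounds with values here, compound 1 `COc1cc(C(=O)/C=C/c2ccc(O)cc2)cc(OC)c1OC` is the only member of the set with a numeric value: in a functional assay on HepG2 cells (Homo sapiens) for inhibition, read by MTT assay, with a stated time of 48 h (a higher number here means a weaker inhibitor, a lower number a stronger inhibitor), compound 1 gives 16000 nM. Compound 2 `COc1ccc(/C=C/C(=O)c2cc(OC)c(OC)c(OC)c2)c(OC)c1` is reported only as a limit, as in this assay compound 2 gives > 100000 nM, a limit of the assay and not a number (the limit of > 100000 nM in this assay, at which 1 of the 2 values shown sits). Compound 3 `COc1cc(C(=O)/C=C/c2ccc(C=O)cc2)cc(OC)c1OC` is not yet measured; it differs from compound 1 by formyl in place of hydroxy on an aromatic carbon. Within the data shown here, no measured step covers this change, so the expected step of a 1.6-fold higher number from compound 1 to compound 3 (0.19 log units; within the scatter) is a slight weakening, barely beyond the scatter. Compound 3 is estimated in this assay at 25000 nM, with a range from 8000 nM to 80000 nM.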

Compound 3, half-maximal inhibitory concentration: > 100000 nM
Compound 3: no number, only a limit; the forecaster's own chance of this, stated with the estimate: 20%; middle value at least 4.0-fold (0.60 log units) from the limit.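

Within the data shown here, at this position, para to a large group, hydroxy and formyl are not interchangeable: in this assay the change from 4-hydroxyphenyl to 4-formylphenyl gives an at least 6.2-fold higher number from compound 1 to compound 3 (0.79 log units; beyond the scatter) on the shared core, the first measured step. Compound 3 gives > 100000 nM, a limit of the assay and not a number, so the step sets only a lower bound on the change: the limit of > 100000 nM in this assay, at which 2 of the 3 values shown sit.

From the compounds shown here alone, whether any group other than hydroxy at this position keeps a numeric value remains open. An amine or a carboxylic acid there would address that.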